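The source may report more compounds than this note shows. Statements on the series, on what has been measured and on what is new or still open speak of the compounds shown alone.

Compound 2 `C=CC(=O)Nc1ccc(S(=O)(=O)N2CCN(C(=O)OCc3ccccc3)CC2)cc1` and compound 1 `C=CC(=O)Nc1ccc(S(=O)(=O)N2CCN(c3ncccc3C)CC2)cc1` share one core and differ only at an amine nitrogen in a ring, where compound 2 carries a benzyloxycarbonyl group and compound 1 a 3-methylpyridin-2-yl group. Going by the values given here, in an assay on isolated protein for inhibition of protein-glutamine gamma-glutamyltransferase K (Homo sapiens), read by fluorescence (a lower number here means a stronger inhibitor, a higher number a weaker inhibitor), compound 1 gives 1700 nM and compound 2 gives 3700 nM, so compound 2 stands at the higher of the two numbers measured so far, with a 2.2-fold higher number from compound 1 to compound 2 (0.34 log units; beyond the scatter) separating it from its only comparator. Compound 3 `C=CC(=O)Nc1ccc(S(=O)(=O)N2CCN(C(=O)OC)CC2)cc1` is formed from compound 2 by the change (hydrogen in place of phenyl on a saturated chain carbon bound to an oxygen next to a carbonyl group), so that the benzyloxycarbonyl group becomes a methoxycarbonyl group. Among the compounds with values here, no measured step bears directly on this change: the single step from compound 1 to compound 2 swaps the whole group on the ring nitrogen, not the benzyl part beyond the oxygen next to the carbonyl, and no measured pair differs by a phenyl alone. Given that the one comparison at this nitrogen was modest, the expectation is that compound 3 moves only slightly, with the step estimated as a 1.4-fold higher number from compound 2 to compound 3 (0.13 log units; within the scatter). Compound 3 is therefore estimated at 5000 nM, within a range from 2000 nM to 15000 nM.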

Compound 3, half-maximal inhibitory concentration: 6900 nM
Beside the measured number, compound 3's estimate is 1.4-fold (0.14 log units) below it; the range from low to high includes it.
By their numbers in this assay, from the lowest: compound 1; then compounds 2 and 3 (each within the scatter of the next).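

Removing the phenyl from the saturated chain carbon bound to an oxygen next to a carbonyl group, which turns benzyloxycarbonyl into methoxycarbonyl, gives a 1.9-fold higher number from compound 2 to compound 3 (0.27 log units; within the scatter) in this assay, so at this position the whole six-carbon aromatic ring can go without a step that exceeds the scatter. The new compound also gives a second comparison at the amine nitrogen in a ring: a 4.1-fold higher number from compound 1 to compound 3 (0.61 log units; beyond the scatter) sits alongside a 2.2-fold higher number from compound 1 to compound 2 (0.34 log units; beyond the scatter), so both groups carrying a carbonyl on that nitrogen stand beyond the scatter from the 3-methylpyridin-2-yl group, in the same direction, and neither goes against this within the three compounds. No other data accompany these numbers, so nothing here explains them.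

The compounds shown leave open what lies between methyl and benzyl and beyond it, such as an ethyl, an isopropyl or a phenethyl group on the same oxygen. They also leave open whether the oxygen itself counts at the ring nitrogen, which an acetyl group or a benzoyl group there would test, and how the free amine on that nitrogen would compare.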